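Working notes: cytotoxicity across a small halogen-swap series

A few compounds are considered here, and "the series" means these few. Any claim that something is new, unique, unknown or untested is made for them only; others in the source may bear on it.

Measured so far in an ADME assay on Vero cells (Chlorocebus sabaeus) for cytotoxicity, read by resazurin assay, with a stated time of 72 h; on this read-out lower numbers stand for stronger inhibition and higher numbers for weaker inhibition:
compound 1, `O=C(CCN1CCN(c2ccc(F)cc2)CC1)c1ccc(F)c(Br)c1`, gives 352000 nM.
compound 2, `O=C(CCN1CCN(c2ccc(C(F)(F)F)cc2)CC1)c1ccc(F)c(Br)c1`, gives 66800 nM.
compound 3, `O=C(CCN1CCN(c2ccc(F)cc2)CC1)c1ccc(F)c(Cl)c1`, gives 185000 nM.

The cores of compound 1 and compound 3 differ only by chloro in place of bromo on an aromatic carbon; in this assay that reads a 1.9-fold lower number from compound 1 to compound 3 (0.28 log units; within the scatter), so the two are not separated. Compound 2 differs from compound 1 by trifluoromethyl in place of fluoro on an aromatic carbon, and here the step is a 5.3-fold lower number from compound 1 to compound 2 (0.72 log units; beyond the scatter), the one clear move in the set so far.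

Compound 4, `O=C(CCN1CCN(c2ccc(C(F)(F)F)cc2)CC1)c1ccc(F)c(Cl)c1`, is not yet measured. It differs from compound 3 by trifluoromethyl in place of fluoro on an aromatic carbon, the same change as from compound 1 to compound 2, made on the core of compound 3 instead. Within the data shown here, compound 2 stands at 66800 nM, which is the only guide to where this change leads.

Among the measured compounds shown here, with only one earlier instance, the expectation for compound 4 is a step of about a 4.6-fold lower number from compound 3 to compound 4 (0.67 log units; beyond the scatter) in this assay, resting on the step of a 5.3-fold lower number from compound 1 to compound 2 (0.72 log units; beyond the scatter) seen in compound 2. Compound 4 is thus estimated at 40000 nM, expected to fall between 15000 nM and 110000 nM.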

Compound 4, half-maximal inhibitory concentration: 74500 nM
The estimate for compound 4 lay 1.9-fold (0.27 log units) below the measured number, within the range that was stated.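

In this assay, trifluoromethyl in place of fluoro again gives a lower number on the chloro-bearing core, a 2.5-fold lower number from compound 3 to compound 4 (0.40 log units; beyond the scatter), so the direction of the change carries over, and the two steps cannot be told apart in size: the same change on two cores in this assay, a 5.3-fold lower number (0.72 log units; beyond the scatter) from compound 1 to compound 2 and a 2.5-fold lower number (0.40 log units; beyond the scatter) from compound 3 to compound 4, 2.1-fold (0.33 log units) apart, within the scatter of two such steps

Chloro in place of bromo leaves the pair unseparated with trifluoromethyl in place as well, a 1.1-fold higher number from compound 2 to compound 4 (0.05 log units; within the scatter), and this swap likewise shows no difference between the two cores: the same change on two cores in this assay, a 1.9-fold lower number (0.28 log units; within the scatter) from compound 1 to compound 3 and a 1.1-fold higher number (0.05 log units; within the scatter) from compound 2 to compound 4, 2.1-fold (0.33 log units) apart, within the scatter of two such steps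

These comparisons rest on a single pair of compounds per core, so they show that the trifluoromethyl step kept its direction across the two cores shown, but they do not show that its size is fixed or that it would carry to any other core.

Open, as far as these compounds go, is whether a nitrile or a methoxy group at the position of the trifluoromethyl would give a step in the same direction. Also open, from the compounds shown here alone, is whether the trifluoromethyl step would keep its direction with a longer chain leading to the carbonyl.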